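Two Difluorophenyl Isomers on a Carbonyl Carbon

The source may report more compounds than this note shows. Statements on the series, on what has been measured and on what is new or still open speak of the compounds shown alone.

For the measured compounds named here, compound 2 `O=C(c1cccc(F)c1F)N1CCc2nc(COc3cccc(F)c3)oc2C1` is one of only two measured compounds. In a functional assay on HEK293 cells for positive allosteric modulation of metabotropic glutamate receptor 5 (Homo sapiens), read by calcium flux (on this read-out higher numbers stand for larger maximal responses and lower numbers for smaller maximal responses), compound 2 gives 72%. Compound 1 `O=C(c1ccccc1)N1CCc2nc(COc3cccc(F)c3)oc2C1` carries a plain phenyl in the same place and in this assay compound 1 gives 73%. Compound 2 thus stands together with compound 1 at essentially the same level: the step of a number 1 percentage points lower from compound 1 to compound 2 (within the scatter) lies within the scatter, so the two compounds cannot be told apart on this read-out.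

Compound 3 `O=C(c1ccc(F)c(F)c1)N1CCc2nc(COc3cccc(F)c3)oc2C1` differs from compound 2 in one place: 3,4-difluorophenyl in place of 2,3-difluorophenyl on a carbonyl carbon. Going by the values given here, the single measured step, a number 1 percentage points lower from compound 1 to compound 2 (within the scatter), bears on the question only loosely. It shows that putting two fluorines onto the phenyl in this position left the largest response unchanged within the scatter. Nothing measured shows what moving those two fluorines to different positions does. The expectation is therefore a step of no size beyond the scatter, with no change at the digits printed from compound 2 to compound 3 (within the scatter) being estimated. Compound 3 is expected to give 72% in this assay, with a range from 58% to 86%.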

Compound 3, largest response reached (reported as percent of maximum), in percent of the reference or control that the assay uses: 71%
Estimate against measurement, compound 3: 1 percentage points above; low and high end bracket the measured number.
By their numbers in this assay, from the lowest: compounds 3, 2 and 1 (each within the scatter of the next).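

Putting 3,4-difluorophenyl in place of 2,3-difluorophenyl on the carbonyl carbon gives a number 1 percentage points lower from compound 2 to compound 3 (within the scatter) in this assay and adds something the earlier pair could not show: on this read-out, these two arrangements of the two fluorines cannot be told apart. Putting 3,4-difluorophenyl in place of the plain phenyl gives a number 2 percentage points lower from compound 1 to compound 3 (within the scatter) in this assay, so this second difluorophenyl also cannot be told apart from the plain phenyl, and the three compounds stand at one level. Nothing available explains this sameness of the largest response across the three groups.

All three compounds shown carry a phenyl ring on the carbonyl carbon, bearing either fluorine or nothing else, so it remains open whether any other kind of group here would shift the largest response. A methoxy group or a chlorine on the phenyl, a pyridine ring in its place, or a saturated ring such as cyclohexyl could show whether this sameness extends beyond the fluorinated phenyl rings.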